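A bromo swap on a compound at the assay limit

The source may report more compounds than this note shows. Statements on the series, on what has been measured and on what is new or still open speak of the compounds shown alone.

Compound 1 `Cc1ccc(C)c(/C=C(/Sc2ccc(Br)cc2)C(=O)c2ccc(Cl)cc2)c1`: 10000 nM
Compound 2 `CN(C)c1ccc(/C=C(/Sc2ccc(Br)cc2)C(=O)c2ccc(Cl)cc2)cc1`: > 100000 nM (a limit)

Both compounds were tested in a functional assay on DU-145 cells (Homo sapiens) for inhibition, read by trypan blue exclusion, with a stated time of 96 h; a higher number here means a weaker inhibitor of growth, a lower number a stronger inhibitor of growth. Compound 2 gives no number and stands at the limit of > 100000 nM in this assay, at which 1 of the 2 values shown sits.

Compound 3 `O=C(/C(=C\c1ccc(Br)cc1)Sc1ccc(Br)cc1)c1ccc(Cl)cc1` has bromo in place of dimethylamino on an aromatic carbon, para to a large group: bromo in place of dimethylamino on an aromatic carbon. The same difference, cut one bond further out, reads 4-(dimethylamino)phenyl to 4-bromophenyl.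

Going by the values given here, one measured step bears on this change: an at least 10-fold higher number from compound 1 to compound 2 (1.00 log units; beyond the scatter), which lies beyond the scatter. That step brought in the 4-(dimethylamino)phenyl that compound 3 gives up. A step of similar size in the opposite direction is therefore expected in this assay, towards a lower number. Among the compounds with values here, its exact size is uncertain, since it starts from a limit and no compound with 4-bromophenyl at this place has been measured. The nearest guide is compound 1 at 10000 nM as a measured value. The step expected is an at least 11-fold lower number from compound 2 to compound 3 (1.04 log units; beyond the scatter). For compound 3 the estimate is 9000 nM, with an expected range from 1500 nM to 50000 nM.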

Compound 3, concentration for 50% growth inhibition: 1000 nM
For compound 3 the middle estimate is 9.0-fold (0.95 log units) above the measured one, and the stated range ends above it.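

In this assay, replacing dimethylamino with bromo on an aromatic carbon, para to a large group, gives an at least 100-fold lower number from compound 2 to compound 3 (2.00 log units; beyond the scatter), so the group at this place has a large bearing on growth inhibition. Compound 2 provides only a limit and not a number, so the full size of that step cannot be read: the limit of > 100000 nM in this assay, at which 1 of the 3 values shown sits. The earlier pair showed only a loss on moving to 4-(dimethylamino)phenyl, whereas 4-bromophenyl in place of 2,5-dimethylphenyl gives a 10-fold lower number from compound 1 to compound 3 (1.00 log units; beyond the scatter), so a change at this place can also yield a stronger inhibitor of growth than compound 1.

The compounds shown leave open whether this gain is specific to bromo or would also appear with chloro, fluoro or methoxy at the same place. They also leave open how a 4-methylphenyl would compare, which would help separate the effect of the group's identity from that of the substitution pattern in the 2,5-dimethylphenyl of compound 1.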